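Trimming the enone of a hexyl-phenyl ketone series

The compounds below may be only part of what the source reports. "The series", "measured", "known", "first", "only" and "open" are said of these compounds alone.

Of the compounds shown here, three with a shared core have been measured in an assay on isolated protein for displacement of a labelled ligand from thyroid hormone receptor alpha (Homo sapiens), read by fluorescence polarization; on this read-out lower numbers stand for stronger inhibition and higher numbers for weaker inhibition. Compound 1 `CCCCCCc1ccc(C(=O)CCN(C(C)C)C(C)C)cc1` gives 4100 nM. Compound 2 `CCCCCCc1ccc(C(=O)/C=C\C(=O)O)cc1` gives 19200 nM. Compound 3 `C=C(C)C(=O)c1ccc(CCCCCCC)cc1` gives 52900 nM, which is the highest of the three numbers: its gap to compound 2 and its larger gap to compound 1 both lie beyond the scatter of repeated measurements, so compound 3 is the weakest of the measured set in this assay.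

Compound 4 `C=CC(=O)c1ccc(CCCCCCC)cc1` has not yet been measured. It differs from compound 3 in a single place: hydrogen in place of methyl on a double-bonded chain carbon bound to a carbonyl carbon. Going by the values given here, no pair of measured compounds shows this particular exchange, so there is no step in this assay to lean on; the expectation rests only on the small size of the change. The author expects the step of a 1.3-fold lower number from compound 3 to compound 4 (0.12 log units; within the scatter) to be modest and within or just beyond the scatter, with no clear direction favoured. For compound 4 the estimate in this assay is 40000 nM, with a range from 15000 nM to 120000 nM.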

Compound 4, half-maximal inhibitory concentration: 23000 nM
Beside the measured number, compound 4's estimate is 1.7-fold (0.24 log units) above it, and the stated range covers the measured number.
By their numbers in this assay, from the lowest: compound 1; then compounds 2 and 4 (each within the scatter of the next); then compound 3.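

In this assay, going by these compounds alone, hydrogen in place of methyl on a double-bonded chain carbon bound to a carbonyl carbon gives a 2.3-fold lower number from compound 3 to compound 4 (0.36 log units; beyond the scatter) as the first step in this set between compounds that differ in one place. It shows that this position is not silent: the loss of one methyl, a single carbon with no ring, hydrogen-bond donor, hydrogen-bond acceptor or net charge involved, moves the number modestly but beyond the scatter, and the methyl-bearing compound 3 has the higher number of the pair. No measurement at hand bears on why the number moves with this exchange.

The compounds shown leave open how other groups would behave in this place, for instance an ethyl group or a fluorine atom on the same double-bonded chain carbon, and so whether the step follows the size of the group at all. They also leave open whether the same exchange would give a step of similar size on a different chain, such as a shorter butyl group on the shared core.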